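Branching the propyl chain on the cyanoguanidine series

The compounds below may be only part of what the source reports. "The series", "measured", "known", "first", "only" and "open" are said of these compounds alone.

Compound 1 `CCC/N=C(\NC#N)Nc1cccnc1`: 20 mg/kg
Compound 2 `CC(C)(C)C/N=C(/NC#N)Nc1cccnc1`: 2.5 mg/kg
Compound 3 `CC(C)/N=C(\NC#N)Nc1cccnc1`: 2.5 mg/kg

Of the compounds shown here, three sharing one core have been tested in a functional assay on the whole organism (blood, strain Wistar-Okamoto) with Rattus norvegicus as the target, with a stated time of 5 days; on this read-out lower numbers stand for an effect already at smaller amounts and higher numbers for an effect only at larger amounts of compound. Compound 1 stands at the highest of the three numbers. Compound 2 gives 2.5 mg/kg, and compound 3 gives 2.5 mg/kg, so both sit well under compound 1.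

Compound 4 `CCC(CC)/N=C(\NC#N)Nc1cccnc1` has not yet been measured. It differs from compound 1 in one place: ethyl in place of hydrogen on a saturated chain carbon bound to a double-bonded nitrogen and a saturated chain carbon. Within the data shown here, the change adds a second branch at the same chain carbon that already carries a branch in compound 3, so the one measured step that bears on it is an 8.0-fold lower number from compound 1 to compound 3 (0.90 log units; beyond the scatter). Compound 2, whose branch sits one carbon further out, shows a number of the same size as compound 3. On that basis a drop of roughly the same size is expected in this assay, that is, an effect at smaller amounts. Compound 4 is therefore expected to give 3 mg/kg, with a range from 1 mg/kg to 10 mg/kg. This estimate means an expected step of a 6.7-fold lower number from compound 1 to compound 4 (0.82 log units; beyond the scatter).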

Compound 4, minimum effective dose: 20 mg/kg
Compound 4: the middle estimate sits 6.7-fold (0.82 log units) below what was measured, and the stated range ends below it.
By their numbers in this assay, from the lowest: compounds 2 and 3 (each within the scatter of the next); then compounds 1 and 4 (each within the scatter of the next).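

In this assay, a branch at this chain carbon does not by itself bring the effect down to smaller amounts. Swapping isopropyl for pentan-3-yl on the double-bonded nitrogen gives a clear loss (an 8.0-fold higher number from compound 3 to compound 4 (0.90 log units; beyond the scatter)), while the ethyl in place of hydrogen leaves the number where the unbranched propyl had it (no change at the digits printed from compound 1 to compound 4 (within the scatter)). So the result depends on which groups the branched carbon carries, not only on branching being present, and nothing shown here explains why.

The compounds shown leave open how a butan-2-yl group, with methyl on one side of that carbon and ethyl on the other, would read out. They also leave open whether tying the chains into a ring, as in cyclopentyl, would give a number like that of compound 3 or that of compound 4.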